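The source may hold more compounds than are shown below. What is called first, only, known or untested is meant among the compounds shown, and "the series" means these compounds.

Among the three compounds measured in an assay for inhibition of Tryptophan 2,3-dioxygenase (Homo sapiens), with stated times of 10 min and 60 min, tested at 10 uM (a lower number here means a weaker effect, a higher number a stronger effect of the compound at the concentration tested), compound 1 `Oc1ccc(CNc2cc(C(F)(F)F)cc3[nH]ncc23)cc1` gives 75%, the highest of the three numbers. Compound 2 `FC(F)(F)c1cc(NC[C@H]2CCCN2)c2cn[nH]c2c1` gives 55%, and compound 3 `O=[N+]([O-])c1cc(OCc2ccccc2)ccc1CNc1cc(C(F)(F)F)cc2[nH]ncc12` gives 49%. Within the data shown here, the one step between compounds that differ in a single place is a number 20 percentage points lower from compound 1 to compound 2 (beyond the scatter), where a pyrrolidin-2-yl group takes the place of the 4-hydroxyphenyl group on a saturated chain carbon bound to a nitrogen on an aromatic ring. Compound 4 `Oc1ccc(CNc2cc(C(F)(F)F)cc3[nH]ncc23)c(Cl)c1` differs from compound 1 by chloro in place of hydrogen on an aromatic carbon; the hydroxy group and the shared core stay as they are. Among the measured compounds shown here, none of the measured steps swaps a hydrogen for a chloro group, so the step from compound 1 to compound 2 offers no guide to its size, and the value of compound 3 concerns a different set of changes. With nothing in the numbers pointing one way, the step in this assay is expected to stay within the usual scatter. Compound 4 is therefore estimated at 75%, between 58% and 88%, an expected step of no change at the digits printed from compound 1 to compound 4 (within the scatter).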

Compound 4, a percentage reported as inhibition, at one concentration (the size of the read-out at that concentration, not a potency): 92%
Beside the measured number, compound 4's estimate is 17 percentage points below it, outside the stated range (above it).
By their numbers in this assay, from the lowest: compounds 3 and 2 (each within the scatter of the next); then compound 1; then compound 4.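

Placing chloro in place of hydrogen on an aromatic carbon, ortho to a large group and meta to a hydroxy group, gives a number 17 percentage points higher from compound 1 to compound 4 (beyond the scatter) in this assay at this single concentration. Among these compounds, the only earlier step replaced the whole 4-hydroxyphenyl group, so it said nothing about this ring carbon; here, adding one chlorine atom and leaving the hydroxy group and the shared core unchanged raises the number beyond the scatter. Nothing measured here explains the rise.

Going by these compounds, whether this gain belongs to chlorine itself remains open, since a fluoro, a bromo or a methyl group on the same carbon could give a smaller, similar or larger number. On these data alone, it is also open whether chloro would give a similar step on another carbon of this ring.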